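From a Cyclohexyl Ether to an Octyl Ether

A few compounds are considered here, and "the series" means these few. Any claim that something is new, unique, unknown or untested is made for them only; others in the source may bear on it.

Measured so far in an assay on SK-BR-3 cells for inhibition of Aromatase (Homo sapiens); a higher number here means a weaker inhibitor, a lower number a stronger inhibitor:
compound 1 `CCCCCCCCCOc1cc([N+](=O)[O-])ccc1NS(C)(=O)=O` gives 910 nM
compound 2 `CN(c1ccc([N+](=O)[O-])cc1OCC1CCCCC1)S(C)(=O)=O` gives 960 nM

Compound 2 holds the highest of the two numbers, but its nearest neighbour, compound 1, lies within the usual scatter of it, so the two cannot be told apart by this assay.

Compound 3 `CCCCCCCCCOc1cc([N+](=O)[O-])ccc1N(C)S(C)(=O)=O` is the next step. It differs from compound 2 in one place: octyl in place of cyclohexyl on a saturated chain carbon bound to an oxygen on an aromatic ring.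

For the measured compounds named here, no step between two measured compounds is known that would show what such a change does here. Going by the values given here, the only guidance is that both measured compounds, with different groups at the ether and at the sulfonamide nitrogen, land close together. The expectation for the step from compound 2 to compound 3 is therefore one of no change beyond the scatter, a 1.0-fold lower number from compound 2 to compound 3 (0.00 log units; within the scatter). Compound 3 is estimated at 950 nM, with a range from 400 nM to 2300 nM.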

Compound 3, half-maximal inhibitory concentration: 3960 nM
For compound 3 the middle estimate is 4.2-fold (0.62 log units) below the measured one; measured number outside the range, above it.
By their numbers in this assay, from the lowest: compounds 1 and 2 (each within the scatter of the next); then compound 3.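

In this assay, this position is sensitive to the group it carries: with methyl on the sulfonamide nitrogen in both compounds, octyl in place of cyclohexyl gives a 4.1-fold higher number from compound 2 to compound 3 (0.62 log units; beyond the scatter), a change beyond the scatter. The sulfonamide nitrogen is sensitive too, as methyl in place of hydrogen, with the ether group unchanged, gives a 4.4-fold higher number from compound 1 to compound 3 (0.64 log units; beyond the scatter), also beyond the scatter. Nothing available here accounts for either step.

Still open is whether the cyclohexyl-to-octyl step would be the same size with hydrogen on the sulfonamide nitrogen, since the compounds shown give this step only with methyl there. Also open, going by these compounds, is how a shorter chain, a phenyl ring or an amine at the end of the chain would behave at this position.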